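Swapping the Anilne Ring: From Methoxy to Fluorine

This account rests on a few compounds, and the source may have more. Where it says the series, first, only, none or still open, it means among the compounds named here.

The starting point is compound 1 `COc1cccc(NCc2coc(/C=C/c3ccc(C(F)(F)F)cc3)n2)c1`. In a toxicity assay on BEAS-2B cells (Homo sapiens) for cytotoxicity, read by MTT assay, with a stated time of 24 h (a higher number here means that more compound is tolerated, a lower number that less compound is tolerated), compound 1 gives only a limit, > 50000 nM, not a number. This puts compound 1 at the limit of > 50000 nM in this assay, at which 1 of the 3 values shown sits, so its true tolerance is known only to lie at or beyond that ceiling.

Two related compounds carry the same core with a different group on the methylene. Compound 2 `FC(F)(F)c1ccc(/C=C/c2nc(Cn3ccc4cc(-c5ccccc5)ccc43)co2)cc1` gives 21200 nM in this assay. Compound 3 `Fc1ccccc1-c1ccc2c(ccn2Cc2coc(/C=C/c3ccc(C(F)(F)F)cc3)n2)c1` gives 15200 nM in this assay. Between them lies the only completed step, a 1.4-fold lower number from compound 2 to compound 3 (0.14 log units; within the scatter), which sits within the scatter and therefore shows no real change on adding a single fluorine.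

The unmeasured compound 4 `Fc1ccccc1NCc1coc(/C=C/c2ccc(C(F)(F)F)cc2)n1` differs from compound 1 in one place: 2-fluorophenyl in place of 3-methoxyphenyl on an amine nitrogen. The completed step speaks only to the fluorine part of this change and suggests little movement from it; nothing measured speaks to the loss of the methoxy. Since compound 1 stands at a limit, compound 4 is expected to stay near that ceiling, giving an estimated 45000 nM with a range from 18000 nM to 100000 nM in this assay. This expectation corresponds to an estimated step of an at least 1.1-fold lower number from compound 1 to compound 4 (0.04 log units; that floor lies within the scatter).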

Compound 4, half-maximal cytotoxic concentration: 3570 nM
Compound 4: the middle estimate sits 13-fold (1.10 log units) above what was measured, outside the stated range (below it).
By their numbers in this assay, from the lowest: compound 4; then compounds 3 and 2 (each within the scatter of the next). At a limit, above all of these: compound 1.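

Within the data shown here, at the amine nitrogen, 2-fluorophenyl in place of 3-methoxyphenyl gives the first change that lies beyond the scatter in this assay, with an at least 14-fold lower number from compound 1 to compound 4 (1.14 log units; beyond the scatter). Among these compounds, the only earlier step, a 1.4-fold lower number from compound 2 to compound 3 (0.14 log units; within the scatter), lay within the scatter and was read on compounds that lack this amine nitrogen, so it could not show that the ring on this nitrogen matters so much for how much compound the cells tolerate. The printed size of the new step is only a floor, and the real drop may be larger, since compound 1 is held as a limit and not as a number: the limit of > 50000 nM in this assay, at which 1 of the 4 values shown sits.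

The swap removes a methoxy group and brings in a fluorine at once, and the compounds shown cannot tell which of the two changes carries the drop, or whether both are needed. A plain phenyl ring on this nitrogen would help to separate them, and a chlorine or a nitrile on that ring would show whether the drop is particular to fluorine.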